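The source may hold more compounds than are shown below. What is called first, only, known or untested is meant among the compounds shown, and "the series" means these compounds.

Measured so far, in an assay on isolated protein for inhibition of calcium/calmodulin-dependent protein kinase type IV (Homo sapiens), read by HTRF, tested at 10 uM; a higher number here means more inhibition at the concentration tested (going by the name of the read-out), a lower number less inhibition:

compound 1, `CN(CCCn1ccnc1)C(=O)[C@@H]1CCCN1c1nccc(Nc2ccccc2)n1`: 0%
compound 2, `COC[C@@H]1CCCN1C(=O)C1CCCN1c1cc(Nc2cccc(Br)c2)ncn1`: 0%
compound 3, `Cc1cccc(Nc2ncnc3c2CN(C(=O)c2ccc(N(C)C)c4ccccc24)CC3)c1`: 0%

Compound 1 stands level with compound 2 and compound 3 at the digits shown; the three values lie within the scatter of one another, and none of the three shows inhibition at the concentration tested. Going by the values given here, no pair among them differs in a single place, so no step between measured compounds is available.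

Compound 4, `CN(C)CC(C)(C)CNC(=O)[C@@H]1CCCN1c1nccc(Nc2ccccc2)n1`, is not yet measured. Compared with compound 1 it carries (2-((dimethylamino)methyl)-2-methylpropyl)amino in place of (3-(1H-imidazol-1-yl)propyl)(methyl)amino on a carbonyl carbon. The rest of the structure is unchanged, including the shared core of compound 1.

With every measured value in this assay at the same flat level, there is no basis for expecting a move in either direction. The step of no change at the digits printed from compound 1 to compound 4 (within the scatter) is expected to be none beyond the scatter. Compound 4 is therefore expected to give 0% in this assay, with a range from -5% to 10%.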

Compound 4, a percentage reported as inhibition, at one concentration (the size of the read-out at that concentration, not a potency): 0%
Compound 4: middle estimate and measured number agree at the digits printed; the measured number falls inside the stated range.
By their numbers in this assay, from the lowest: compounds 1, 2, 3 and 4 (each within the scatter of the next).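

In this assay, going by these compounds alone, the exchange of (3-(1H-imidazol-1-yl)propyl)(methyl)amino for (2-((dimethylamino)methyl)-2-methylpropyl)amino on a carbonyl carbon is the first single-place comparison, and it gives no change at the digits printed from compound 1 to compound 4 (within the scatter). The exchange removes the five-membered aromatic ring with 2 hetero atoms and brings in 1 hydrogen-bond donor, yet compound 4 reads 0%, so neither the ring nor the tertiary amide of compound 1 is needed to hold this reading. No measured finding bears on this result, and its origin remains unexplained.

From the compounds shown here alone, whether a piperazine or a carboxylic acid on this carbonyl carbon would give any reading different from that of compound 4 remains open. Going by these compounds, with all four compounds level in this assay, it is also open whether a change elsewhere on the shared core would register at all.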